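Cytotoxicity notes: thiazolyl in place of acetyl

This account rests on a few compounds, and the source may have more. Where it says the series, first, only, none or still open, it means among the compounds named here.

Compound 2 `CC(=O)c1cccc(NC(=O)C2CCCN(C(=O)c3cc(C(F)(F)F)cc(C(F)(F)F)c3)C2)c1` gives 0% in an ADME assay on PC-3 cells (Homo sapiens) for cytotoxicity, read by WST assay, tested at 100 uM; on this read-out higher numbers stand for more inhibition at the one concentration tested (going by the name of the read-out) and lower numbers for less inhibition. Compound 3 `C=Cc1cccc(C(=O)N2CCCC(C(=O)Nc3ccc(Cl)cc3)C2)c1` gives 0% in this assay, level with compound 2 at the digits shown, and the pair are together the lowest of the three numbers. Furthest from compound 2 is compound 1 `CS(=O)(=O)Nc1cccc(C(=O)N2CCCC(C(=O)Nc3ccc(Cl)cc3)C2)c1`, which gives 3%, a gap within the scatter. Within the data shown here, the one step measured, a number 3 percentage points lower from compound 1 to compound 3 (within the scatter), is likewise within the scatter. Compound 4 `Cc1nc(-c2cccc(NC(=O)C3CCCN(C(=O)c4cc(C(F)(F)F)cc(C(F)(F)F)c4)C3)c2)cs1` differs from compound 2 by 2-methyl-1,3-thiazol-4-yl in place of acetyl on an aromatic carbon. Among the measured compounds shown here, no measured step touches this change; with every number low and the one step flat, a step of a number 3 percentage points higher from compound 2 to compound 4 (within the scatter) is expected, none beyond the scatter. Compound 4 is therefore estimated at 3%, in the range -6% to 16%.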

Compound 4, a percentage reported as inhibition, at one concentration (the size of the read-out at that concentration, not a potency): 1%
For compound 4 the middle estimate is 2 percentage points above the measured one, and the stated range covers the measured number.
By their numbers in this assay, from the lowest: compounds 2, 3, 4 and 1 (each within the scatter of the next).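

In this assay, the step to the larger 2-methyl-1,3-thiazol-4-yl group on this aromatic carbon is a number 1 percentage points higher from compound 2 to compound 4 (within the scatter), so replacing acetyl with a five-membered aromatic ring leaves the read-out flat. This is the first step shown at this position of the core of compound 2, and the earlier step lay on the core of compound 1. No evidence bears on this result.

On these data alone, whether an amine or a carboxylic acid at this aromatic carbon would give a number beyond the scatter stays open. So does whether the flat step would hold with the 4-chlorophenyl amide of compound 1 in place of the core of compound 2.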